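Hydroxy in place of fluoro: from compound 3 to compound 4

The source may report more compounds than this note shows. Statements on the series, on what has been measured and on what is new or still open speak of the compounds shown alone.

Measured so far in a functional assay on RCC4 cells (Homo sapiens) for inhibition, read by XTT assay, with a stated time of 4 days; a higher number here means a weaker inhibitor, a lower number a stronger inhibitor:
- compound 1, `Cc1cccc(Nc2nc(-c3ccncc3C#CCCCO)cs2)c1`: 6300 nM; 1120 nM (2 entries)
- compound 2, `FC(F)(F)c1ccccc1Nc1nc(-c2ccncc2)cs1`: 40700 nM
- compound 3, `Fc1ccccc1Nc1nc(-c2ccncc2)cs1`: 14500 nM

Compound 3 carries fluoro on the ring that bears the amine link, and in this assay compound 3 gives the lowest of the two single numbers recorded. Its nearest neighbour is compound 2, and the step of a 2.8-fold lower number from compound 2 to compound 3 (0.45 log units; beyond the scatter) runs in favour of compound 3. Compound 1 has no single number; its two entries, (the several entries of compound 1 in this assay, 6300 nM; 1120 nM (2 entries)), bracket the value of compound 3 from both sides, so nothing firm can be said of the order between compound 1 and compound 3.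

Compound 4, `Oc1ccccc1Nc1nc(-c2ccncc2)cs1`, is compound 3 with one change: hydroxy in place of fluoro on an aromatic carbon. Among the measured compounds shown here, only one measured step touches this part of the molecule, the swap of trifluoromethyl for fluoro between compound 2 and compound 3, and it was modest. For the measured compounds named here, no measured step tells how hydroxy behaves at this place. The expectation for compound 4 in this assay is therefore a step of a 1.5-fold lower number from compound 3 to compound 4 (0.16 log units; within the scatter) that stays within the scatter, in either direction. Compound 4 is estimated at 10000 nM, with a range from 3000 nM to 40000 nM.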

Compound 4, half-maximal inhibitory concentration: 12900 nM
Beside the measured number, compound 4's estimate is 1.3-fold (0.11 log units) below it; the range from low to high includes it.
By their numbers in this assay, from the lowest: compounds 4 and 3 (each within the scatter of the next); then compound 2.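

In this assay, the aromatic carbon ortho to a large group now carries three groups, and the first hydroxy entry adds a new kind of change: 1 hydrogen-bond donor and 1 hydrogen-bond acceptor enter where fluoro had neither, yet the result is a 1.1-fold lower number from compound 3 to compound 4 (0.05 log units; within the scatter), so this exchange gives no readable difference. Trifluoromethyl now stands apart from both smaller groups, since a 3.2-fold lower number from compound 2 to compound 4 (0.50 log units; beyond the scatter) comes on top of the earlier 2.8-fold lower number from compound 2 to compound 3 (0.45 log units; beyond the scatter), and among these three compounds none goes against that split, although both steps are modest and all three numbers remain high. No measurement shown bears on why fluoro and hydroxy read alike at this place, and the entries of compound 1 do not address it.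

Methoxy would show whether the hydrogen on hydroxy matters at this place, while an amine or a carboxylic acid would test whether the readings stay level with a different group there. Chloro or methyl would help show whether the trifluoromethyl reading stands alone or belongs to a wider set of groups.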